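A few compounds are considered here, and "the series" means these few. Any claim that something is new, unique, unknown or untested is made for them only; others in the source may bear on it.

Two compounds carry the shared core of compound 1 `Cn1ncc(Cl)c1-c1cc(C(=O)N[C@@H]2CN[C@H](CCO)C[C@H]2c2ccc(F)c(F)c2)oc1Cl`, and compound 1, with a hydroxyethyl group on its saturated ring, is the stronger of the pair: in a functional assay on OVCAR-8 cells (Homo sapiens) for antiproliferative activity (a lower number here means a stronger inhibitor, a higher number a weaker inhibitor), compound 1 gives 460 nM. Compound 2 `Cn1ncc(Cl)c1-c1cc(C(=O)N[C@@H]2CN[C@H](CCN3CCCCC3)C[C@H]2c2ccc(Cl)c(Cl)c2)oc1Cl`, which has a 2-(piperidin-1-yl)ethyl group in the same position and a dichlorophenyl substituent on its saturated ring, stands at the weaker end of the two numbers: in this assay compound 2 gives 1660 nM, a gap to compound 1 that lies beyond the usual scatter. The next compound is compound 3 `Cn1ncc(Cl)c1-c1cc(C(=O)N[C@@H]2CN[C@H](CC(=O)NC3CCC3)C[C@H]2c2ccc(Cl)c(Cl)c2)oc1Cl`, which differs from compound 2 in one place: cyclobutylcarbamoyl in place of (piperidin-1-yl)methyl on a saturated chain carbon bound to a saturated ring carbon. Going by the values given here, no measured pair shows this exchange, so the size of its effect is unknown. Among the compounds with values here, with only compound 2 and compound 1 as points of reference, and no matched pair to lean on, a small step from compound 2 to compound 3 is expected, at most modestly toward a lower number, and possibly none beyond the scatter, so that the estimated step is a 1.4-fold lower number from compound 2 to compound 3 (0.14 log units; within the scatter). In this assay compound 3 is expected to give about 1200 nM, within a range of 400 nM to 3600 nM.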

Compound 3, half-maximal inhibitory concentration: 610 nM
Beside the measured number, compound 3's estimate is 2.0-fold (0.29 log units) above it; low and high end bracket the measured number.
By their numbers in this assay, from the lowest: compounds 1 and 3 (each within the scatter of the next); then compound 2.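

In this assay, going by these compounds alone, the exchange of (piperidin-1-yl)methyl for cyclobutylcarbamoyl gives the first reading at this place with everything else in the molecule held the same: a 2.7-fold lower number from compound 2 to compound 3 (0.43 log units; beyond the scatter). Compounds 1 and 2 differ in more than one place, so their gap could not be assigned to this side chain, whereas this step shows that the group on the saturated chain carbon bound to a saturated ring carbon does by itself move the number beyond the scatter. The two groups have the same count of heavy atoms, so the step comes with a change in the kind of group at equal heavy-atom count, and no measurement shown here accounts for it.

The exchange replaces the six-membered ring, its nitrogen and the chain together with a carbonyl, an amide hydrogen and a four-membered ring, so the compounds shown do not separate which of these parts carries the step. On these data alone, it also remains open how a carboxylic acid, a primary amine or a longer chain would read at this place, and whether the same exchange would give a similar step with the difluorophenyl group of compound 1.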